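The compounds below may be only part of what the source reports. "The series", "measured", "known", "first", "only" and "open" are said of these compounds alone.

Three compounds of this series have been run in a functional assay on HeLa cells (Homo sapiens) for cytotoxicity, read by MTT assay, with a stated time of 72 h; a lower number here means a stronger inhibitor, a higher number a weaker inhibitor. Compound 1 `Cc1cccc(CSc2cc(Cl)c(C)cc2S(=O)(=O)/N=C(\N)n2nc(C)cc2-c2ccccc2)c1` gives 155000 nM, compound 2 `Cc1cc(-c2ccccc2)n(/C(N)=N/S(=O)(=O)c2cc(C)c(Cl)cc2SCc2ccccc2)n1` gives 5000 nM, and compound 3 `Cc1cc(S(=O)(=O)/N=C(\N)n2nccc2-c2ccccc2)c(SCc2ccccc2C(F)(F)F)cc1Cl` gives 20000 nM. Among the compounds with values here, the single counted step is methyl in place of hydrogen on an aromatic carbon, placed on an aromatic carbon of a six-membered aromatic ring of carbon only, meta to a large group; it reads a 31-fold higher number from compound 2 to compound 1 (1.49 log units; beyond the scatter). The difference between the cores of compound 2 and compound 3 is not broken down here; their values alone show compound 3 as the higher number.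

Compound 4 `Cc1cc(-c2ccccc2)n(/C(N)=N/S(=O)(=O)c2cc(C)c(Cl)cc2SCc2ccccc2C(F)(F)F)n1`, not yet measured, differs from compound 3 by methyl in place of hydrogen on an aromatic carbon. This is the same kind of change as that from compound 2 to compound 1, not the same: here the methyl enters an aromatic carbon of a five-membered aromatic ring with 2 nitrogen, next to the ring nitrogen, rather than the carbon ring. With no measured methyl at this place, the step is expected to be a 1.3-fold lower number from compound 3 to compound 4 (0.12 log units; within the scatter), smaller than the earlier one and uncertain in direction. Compound 4 is therefore estimated at 15000 nM, between 4000 nM and 60000 nM.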

Compound 4, half-maximal inhibitory concentration: 215000 nM
The estimate for compound 4 lay 14-fold (1.16 log units) below the measured number, outside the stated range (above it).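

In this assay the methyl step reads an 11-fold higher number from compound 3 to compound 4 (1.03 log units; beyond the scatter) in the same direction as the earlier step, but the two sizes differ: the same change on two cores in this assay, a 31-fold higher number (1.49 log units; beyond the scatter) from compound 2 to compound 1 and an 11-fold higher number (1.03 log units; beyond the scatter) from compound 3 to compound 4, 2.9-fold (0.46 log units) apart, beyond the scatter of two such steps. The direction therefore carries across these two cores and the size does not, and two cores give no rule for any other core. Trifluoromethyl in place of hydrogen reads a 43-fold higher number from compound 2 to compound 4 (1.63 log units; beyond the scatter) while 2-(trifluoromethyl)phenyl in place of 3-methylphenyl reads a 1.4-fold higher number from compound 1 to compound 4 (0.14 log units; within the scatter) and so does not separate that pair.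

Still open, going by these compounds, is what a larger or different group does on the same carbon of the five-membered ring. An ethyl, an amine or a carboxylic acid there would show whether the rise in the number is particular to methyl.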